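Ring swap on the chain of compound 2

The compounds below may be only part of what the source reports. "The series", "measured", "known", "first", "only" and "open" are said of these compounds alone.

Of the compounds shown here, three have been tested in a functional assay on K562 cells (Homo sapiens) for cytotoxicity, read by MTT assay; on this read-out lower numbers stand for higher toxicity in this test and higher numbers for lower toxicity in this test. Compound 1 `CC1=C(O)/C(=C/[C@H](C)CCC/C(C)=C/CC/C(C)=C/CCC2=CC(O)OC2=O)OC1=O` gives > 100 ug/mL, which is a limit of the assay and not a number. Compound 3 `COC(=O)C(C)(O)[C@](O)(C[C@H](C)CC/C=C(/C)CC/C=C(/C)CCCC1=CCN(CC(=O)O)C1=O)C(=O)OC` likewise gives > 100 ug/mL, again a limit. Compound 2 `COC1C=C(CCC/C(C)=C\CC/C(C)=C\CC[C@@H](C)/C=C2\OC(=O)C(C)=C2O)C(OC)O1` gives 83 ug/mL and so holds the only number shown. Compounds 1 and 3 sit at the limit, as the limit of > 100 ug/mL in this assay, at which 2 of the 3 values shown sit, records. Going by the values given here, no two measured compounds differ in a single place, so no measured step can be followed.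

Compound 4 `CC1=C(O)/C(=C/[C@H](C)CC/C=C(/C)CC/C=C(/C)CCCC2=CC(=O)OC2O)OC1=O` remains to be measured in this assay. It differs from compound 2 by a group of 7 heavy atoms (4 carbon, 3 oxygen; one five-membered non-aromatic ring with 1 hetero atom) in place of a group of 9 heavy atoms (6 carbon, 3 oxygen; one five-membered non-aromatic ring with 1 hetero atom), on a saturated chain carbon, three bonds along the chain from a double-bonded chain carbon. Among the compounds with values here, with no measured step to lean on, the expectation rests on compound 2 with 83 ug/mL. It also takes into account that compounds 1 and 3 sit at the limit, as the limit of > 100 ug/mL in this assay, at which 2 of the 3 values shown sit, records. The step of a 1.1-fold higher number from compound 2 to compound 4 (0.04 log units; within the scatter) is expected to be small, within the usual scatter, and if anything towards the limit. Compound 4 is accordingly estimated at 90 ug/mL, between 40 ug/mL and 200 ug/mL.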

Compound 4, concentration lethal to 50% of the cells: > 100 ug/mL
Compound 4: a limit, no number; the forecaster's own chance of this, stated with the estimate: 50%; middle value at least 1.1-fold (0.04 log units) from the limit.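

The change at this saturated chain carbon, three bonds along the chain from a double-bonded chain carbon, now has a measured step in this assay: an at least 1.2-fold higher number from compound 2 to compound 4 (0.08 log units; that floor lies within the scatter). The value of compound 4 is a limit and not a number, so only the floor of this step is known, and the data do not establish a real change on replacing the group of 9 heavy atoms with the group of 7 heavy atoms. The new result adds one more compound to the upper end of the read-out: the limit of > 100 ug/mL in this assay, at which 3 of the 4 values shown sit.

Going by these compounds, how far the step extends past its floor remains open. On these data alone, what a primary amine or a phenyl ring would give at this chain carbon also remains open.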